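Trifluoromethyl for methyl on the phenol of compound 1

This account rests on a few compounds, and the source may have more. Where it says the series, first, only, none or still open, it means among the compounds named here.

Three compounds on a shared core have numbers in an assay on isolated protein for inhibition of Dopamine beta-hydroxylase (Rattus norvegicus); a higher number here means a weaker inhibitor, a lower number a stronger inhibitor. Compound 1 `Cc1cc(Cn2cc[nH]c2=S)ccc1O` gives 49000 nM, the lowest of the three. Compound 3 `S=c1[nH]ccn1Cc1ccc(Br)cc1` gives 115000 nM, and compound 2 `S=c1[nH]ccn1Cc1ccccc1Cl` gives 355000 nM. Both gaps from compound 1 lie beyond the usual scatter, so compound 1 stands as the strongest inhibitor of the three shown. Within the data shown here, no step between two measured compounds differs in a single place, so the set offers no direct guide for the next change.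

Compound 4 `Oc1ccc(Cn2cc[nH]c2=S)cc1C(F)(F)F` follows from compound 1 by trifluoromethyl in place of methyl on an aromatic carbon, ortho to a hydroxy group. Among the measured compounds shown here, with no comparable step on record, the expectation for a 1.2-fold lower number from compound 1 to compound 4 (0.09 log units; within the scatter) is a move of no more than the scatter in either direction. On that basis compound 4 is estimated at 40000 nM in this assay, with a range from 15000 nM to 120000 nM, pending the measurement.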

Compound 4, half-maximal inhibitory concentration: 120000 nM
Compound 4: the middle estimate sits 3.0-fold (0.48 log units) below what was measured; low and high end bracket the measured number.
By their numbers in this assay, from the lowest: compound 1; then compounds 3 and 4 (each within the scatter of the next); then compound 2.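

In this assay, the series now has its first step that differs in one place: a 2.4-fold higher number from compound 1 to compound 4 (0.39 log units; beyond the scatter). At this aromatic carbon, ortho to a hydroxy group, trifluoromethyl in place of methyl weakens inhibition beyond the scatter, so the position is sensitive to this change and methyl is the better of the two groups. The hydrogen-bond donor and acceptor counts of the two groups are the same, and no measurement on hand bears on why the number rises.

The compounds shown leave open whether the methyl of compound 1 adds to inhibition at all, a question that hydrogen, chlorine or ethyl at the same carbon would address. They also leave open how much the hydroxy group contributes, which a methoxy group in its place would test.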